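A few compounds are considered here, and "the series" means these few. Any claim that something is new, unique, unknown or untested is made for them only; others in the source may bear on it.

Working notes on the series. Compound 1 `O=C1COc2ccc(-c3cccc(NS(=O)(=O)c4ccc(F)cc4)c3)cc2N1c1ccccc1` carries phenyl on an amide-type nitrogen in a ring, and in a functional assay on HepG2 cells (Homo sapiens) for antiproliferative activity, read by MTT assay, with a stated time of 72 h (a higher number here means a weaker inhibitor, a lower number a stronger inhibitor), compound 1 gives 30300 nM. Compound 2 `O=C1COc2ccc(-c3ccc(O)cc3)cc2N1`, a simpler variant of the same core, gives in this assay 38200 nM, and compounds 1 and 2 lie within the scatter of one another. Compound 3 `CC(C)N1C(=O)COc2ccc(-c3cccc(NS(=O)(=O)c4ccc(F)cc4)c3)cc21` carries isopropyl on that nitrogen. In this assay compound 3 gives > 40000 nM, which is the limit of > 40000 nM in this assay, at which 1 of the 3 values shown sits, and not a number. The step of an at least 1.3-fold higher number from compound 1 to compound 3 (0.12 log units; that floor lies within the scatter) is thus only a floor, and compound 3 stands at the limit rather than at a measured point.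

Compound 4 `O=C1COc2ccc(-c3cccc(NS(=O)(=O)c4ccc(F)cc4)c3)cc2N1c1ccc(F)cc1` differs from compound 3 by 4-fluorophenyl in place of isopropyl on an amide-type nitrogen in a ring. Among the measured compounds shown here, the only measured step that bears on this change is an at least 1.3-fold higher number from compound 1 to compound 3 (0.12 log units; that floor lies within the scatter), taken in the reverse sense, and its floor lies within the scatter, so compound 4 is expected to return to roughly where compound 1 sits, the expected step being an at least 1.3-fold lower number from compound 3 to compound 4 (0.12 log units; that floor lies within the scatter). Compound 4 is estimated in this assay at 30000 nM, within a range from 15000 nM to 60000 nM.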

Compound 4, half-maximal inhibitory concentration: > 40000 nM
Compound 4: no number, only a limit; the forecaster's own chance of this, stated with the estimate: 35%; middle value at least 1.3-fold (0.12 log units) away from the limit.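

In this assay compound 4 ends at a limit and not at a number, and the step from compound 3 cannot be read, as both ends are limits: the limit of > 40000 nM in this assay, at which 2 of the 4 values shown sit.

Fluoro in place of hydrogen on an aromatic carbon gives an at least 1.3-fold higher number from compound 1 to compound 4 (0.12 log units; that floor lies within the scatter), so this change is bounded on one side only. Phenyl on the amide-type nitrogen in a ring goes with a number in compound 1, while 4-fluorophenyl at the same place goes with a limit in compound 4, so an aromatic ring on this nitrogen does not alone secure a number.

Going by these compounds, how far compound 3 and compound 4 lie past the limit stays open. Also open, on these data alone, is whether an amine, a carboxylic acid or a longer chain on this nitrogen would give a value clear of the limit.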